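The source may report more compounds than this note shows. Statements on the series, on what has been measured and on what is new or still open speak of the compounds shown alone.

Measured so far:
- compound 1 `COc1cc(C)[nH]c(=O)c1CN1CCc2c(Cl)cc(-c3c(C)noc3C)c(Cl)c2C1=O`: 8 nM
- compound 2 `Cc1cc(C)c(CN2CCc3c(Cl)cc([C@H](C)CO)c(Cl)c3C2=O)c(=O)[nH]1`: 129 nM
- compound 3 `Cc1cc(C)c(CN2CCc3c(Cl)cc(C(CO)C4CCOC4)c(Cl)c3C2=O)c(=O)[nH]1`: 1010 nM; 15 nM (2 entries)

In an assay on cells for inhibition of histone-lysine N-methyltransferase EZH2 (Homo sapiens), read by ELISA, with a stated time of 72 h (a lower number here means a stronger inhibitor, a higher number a weaker inhibitor), compound 1 gives 8 nM, the lowest of the two single numbers in this set. Compound 2 gives 129 nM, a gap that lies beyond the scatter of the measurement. Compound 3 has no single number: the several entries of compound 3 in this assay, 1010 nM; 15 nM (2 entries) shows two values far apart, so it cannot be placed against compound 1 with any confidence.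

The compound now to be measured is compound 4 `COc1cc(C)[nH]c(=O)c1CN1CCc2c(Cl)cc([C@@H](O)C3COC3)c(Cl)c2C1=O`. It keeps the core and the chloro-bearing ring of compound 1 and changes only the group on the aromatic carbon: a group of 6 heavy atoms (4 carbon, 2 oxygen; one four-membered non-aromatic ring with 1 hetero atom) in place of a group of 7 heavy atoms (5 carbon, 1 nitrogen, 1 oxygen; one five-membered aromatic ring with 2 hetero atoms), on an aromatic carbon. That is, the 3,5-dimethyl-1,2-oxazol-4-yl group leaves and a hydroxymethyl-oxetane group with one defined stereocentre enters.

Among the compounds with values here, no measured pair differing in one place is available, so the size of this step can only be expected. Compounds 2 and 3 carry hydroxyl-bearing groups at the same place on a related core, and their values do not reach that of compound 1, so a move toward a weaker inhibitor is expected, of a modest size, from compound 1 to compound 4 a 5.0-fold higher number from compound 1 to compound 4 (0.70 log units; beyond the scatter). In this assay compound 4 is estimated at 40 nM, in a range from 10 nM to 200 nM.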

Compound 4, half-maximal inhibitory concentration in the histone-lysine N-methyltransferase EZH2 assay: > 32000 nM
Compound 4: no number, only a limit (the forecaster's own chance of this, stated with the estimate: 3%); middle value at least 800-fold (2.90 log units) away from the limit.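

In the histone-lysine N-methyltransferase EZH2 assay compound 4 gives > 32000 nM as its reading, which is a limit and not a number: the limit of > 32000 nM in the histone-lysine N-methyltransferase EZH2 assay, at which 1 of the 4 values shown sits. Read with that limit, replacing the 3,5-dimethyl-1,2-oxazol-4-yl group with a hydroxyl-bearing group with a four-membered non-aromatic ring gives an at least 4000-fold higher number from compound 1 to compound 4 (3.60 log units; beyond the scatter), the first single-place step in this set, and it shows that a similar-sized group at this aromatic carbon, ortho to a chloro group, can abolish measurable inhibition on the shared core. In a physicochemical assay for solubility, measured as kinetic solubility (a higher number here means a more soluble compound, a lower number a less soluble compound), compound 1 gives 384000 nM and compound 4 gives 582000 nM with the same exchange, which amounts to a 1.5-fold higher number from compound 1 to compound 4 (0.18 log units; within the scatter), so the two compounds cannot be told apart there, and the large step in inhibition comes without a separation in solubility.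

The compounds shown do not separate the contributions of the hydroxyl group, the four-membered ring, the defined stereocentre and the loss of the five-membered aromatic ring, and the limit leaves the true size of the step open. Also open, as far as these compounds go, is whether a pyrazole, a simple amine or the opposite stereoisomer of the entering group at this carbon would retain inhibition on this core.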